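The source may hold more compounds than are shown below. What is called first, only, known or untested is meant among the compounds shown, and "the series" means these compounds.

Measured so far in a functional assay on CHO cells with adenosine receptor A1 (Homo sapiens) as the target, read by cAMP accumulation and immunoassay, with a stated time of 6 min, tested at 10 uM; on this read-out higher numbers stand for a weaker effect at the one concentration tested and lower numbers for a stronger effect:
- Compound 1 `Nc1scc(CN2CCN(c3ccc(OC(F)(F)F)cc3)CC2)c1C(=O)c1ccc(Cl)cc1` gives -74%
- Compound 2 `Nc1scc(CN2CCN(c3cccc4ccccc34)CC2)c1C(=O)c1ccc(Cl)cc1` gives -21%
- Compound 3 `Nc1scc(CN2CCN(c3cccc(F)c3)CC2)c1C(=O)c1ccc(Cl)cc1` gives -82%

Compound 3 has the lowest of the three numbers in this assay. Its nearest neighbour is compound 1, and the gap between them, a number 8 percentage points lower from compound 1 to compound 3 (within the scatter), lies within the scatter, so no order between compound 3 and compound 1 can be claimed. Its furthest neighbour is compound 2, with the gap a number 61 percentage points lower from compound 2 to compound 3 (beyond the scatter), which is large and beyond the scatter, as is a number 53 percentage points higher from compound 1 to compound 2 (beyond the scatter).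

Compound 4 `Nc1scc(CN2CCN(c3cccc(Cl)c3)CC2)c1C(=O)c1ccc(Cl)cc1` differs from compound 3 by chloro in place of fluoro on an aromatic carbon, on an aromatic carbon of a six-membered aromatic ring of carbon only, meta to a large group. Within the data shown here, no measured step matches this exchange of one halogen for another. The step that bears most closely on it is a number 8 percentage points lower from compound 1 to compound 3 (within the scatter), a small exchange of the group on this ring that stayed within the scatter, whereas the large shifts came only when the whole ring was exchanged for naphthalen-1-yl, as in a number 61 percentage points lower from compound 2 to compound 3 (beyond the scatter). Compound 4 is therefore expected to stay close to compound 3, with a step of a number 4 percentage points higher from compound 3 to compound 4 (within the scatter) that is not expected to exceed the scatter. The estimate for compound 4 in this assay is -78%, ranging from -95% to -55%.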

Compound 4, a percentage reported as activity, at one concentration (the size of the read-out at that concentration, not a potency): -77%
Estimate against measurement, compound 4: 1 percentage points below; the measured number falls inside the stated range.
By their numbers in this assay, from the lowest: compounds 3, 4 and 1 (each within the scatter of the next); then compound 2.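

In this assay, among these compounds, chloro in place of fluoro on an aromatic carbon, meta to a large group, gives a number 5 percentage points higher from compound 3 to compound 4 (within the scatter), the first direct exchange of one halogen for another at this place, and the read-out shows no change that can be told from scatter. The 3-chlorophenyl group likewise cannot be separated from the 4-(trifluoromethoxy)phenyl group, with a number 3 percentage points lower from compound 1 to compound 4 (within the scatter), while the gap to the naphthalen-1-yl group remains wide, at a number 56 percentage points lower from compound 2 to compound 4 (beyond the scatter). The 3-fluorophenyl and 3-chlorophenyl groups therefore both sit level with the 4-(trifluoromethoxy)phenyl group and apart from the naphthalen-1-yl group, although a read-out at one concentration cannot show whether any potency difference lies hidden among the three level compounds.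

The compounds shown leave open whether this place tolerates only halogens or also keeps the same read-out with bromo, methoxy, an amine or a carboxylic acid on the same aromatic carbon. No evidence is at hand that would explain these steps.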